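Adding a Methyl to the Side Chain of Compound 1

The source may hold more compounds than are shown below. What is called first, only, known or untested is meant among the compounds shown, and "the series" means these compounds.

Compound 1 `COc1ccc(-c2cc3cc(C4C(C#N)=C(N)OC5=C4C(=O)CCC5)cc(C(C)C)c3oc2=O)cc1` stands higher of the two measured compounds: in a functional assay on the whole organism (strain Swiss albino) with Mus musculus as the target, in the forced swim test, with a stated time of 5 min, at a dose of 0.5 mg/kg by the intraperitoneal route (a lower number here means less inhibition, a higher number more inhibition at the dose given (going by the name of the read-out)), compound 1 gives 69.7%, while compound 2 `COc1cc(-c2cc3cc(C4C(C#N)=C(N)OC5=C4C(=O)CCC5)cc(C(C)C)c3oc2=O)cc(OC)c1OC` gives 31.9%. That single known step, a number 37.8 percentage points lower from compound 1 to compound 2 (beyond the scatter), alters the 4-methoxyphenyl group rather than the isopropyl chain. Compound 3 `CCC(C)c1cc(C2C(C#N)=C(N)OC3=C2C(=O)CCC3)cc2cc(-c3ccc(OC)cc3)c(=O)oc12` differs from compound 1 by methyl in place of hydrogen on a saturated chain carbon, two bonds along the chain from an aromatic carbon. Among the compounds with values here, no measured step touches this chain, so nothing seen so far bears on it directly, and a change no larger than the scatter is expected, a number 4.7 percentage points lower from compound 1 to compound 3 (within the scatter). Compound 3 is therefore estimated at 65%, within a range from 45% to 85%.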

Compound 3, a percentage reported as inhibition, in the whole organism at one dose (the size of the read-out at that dose, not a potency): 35.1%
The estimate for compound 3 lay 29.9 percentage points above the measured number, outside the stated range (below it).
By their numbers in this assay, from the lowest: compounds 2 and 3 (each within the scatter of the next); then compound 1.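

Going from isopropyl to sec-butyl in this assay gives a number 34.6 percentage points lower from compound 1 to compound 3 (beyond the scatter) and so shows that the side chain matters, not only the 4-methoxyphenyl group changed in the earlier step. One added methyl on this saturated chain carbon is enough to produce a large step at this dose. Nothing at hand explains why the number falls with this methyl.

As far as these compounds go, whether a tert-butyl group or a longer chain such as pentyl would lower the number further at this place remains open. So does whether the same methyl has a similar effect when 3,4,5-trimethoxyphenyl replaces 4-methoxyphenyl.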